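The source may report more compounds than this note shows. Statements on the series, on what has been measured and on what is new or still open speak of the compounds shown alone.

Measured in a functional assay on HepG2 cells (Homo sapiens) for inhibition, read by MTT assay, with a stated time of 72 h; on this read-out higher numbers stand for weaker inhibition and lower numbers for stronger inhibition:
compound 1 `O=C(OC1(C(=O)Nc2ccc([N+](=O)[O-])cc2)CCCCC1)c1ccc(Cl)cc1` — 21.8 nM
compound 2 `COc1ccc(C(=O)OC2(C(=O)Nc3ccc([N+](=O)[O-])cc3)CCCCC2)cc1` — 57.1 nM
compound 3 `O=C(OC1(C(=O)Nc2ccc([N+](=O)[O-])cc2)CCCCC1)c1ccc([N+](=O)[O-])cc1` — 14.1 nM

Compound 1 stands second highest of the three numbers; compound 3 is nearest, with a 1.5-fold lower number from compound 1 to compound 3 (0.19 log units; within the scatter), and compound 2 furthest, with a 2.6-fold higher number from compound 1 to compound 2 (0.42 log units; beyond the scatter). Compound 4 `O=C(/C=C/c1ccccc1)OC1(C(=O)Nc2ccc([N+](=O)[O-])cc2)CCCCC1` alters the ester side of the shared core: 2-phenylethenyl in place of 4-chlorophenyl on a carbonyl carbon. For the measured compounds named here, no measured step touches this kind of exchange; the steps on record only swap substituents on the ester's phenyl ring, and even the largest of them, a 4.0-fold lower number from compound 2 to compound 3 (0.61 log units; beyond the scatter), is modest. The step to compound 4 replaces the whole aryl group, so it is expected to be small in this assay, direction uncertain, and it is put at a 1.6-fold higher number from compound 1 to compound 4 (0.21 log units; within the scatter). Compound 4 is therefore estimated at 35 nM, with a range from 12 nM to 100 nM.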

Compound 4, half-maximal inhibitory concentration: 52.9 nM
For compound 4 the middle estimate is 1.5-fold (0.18 log units) below the measured one; the measured number falls inside the stated range.
By their numbers in this assay, from the lowest: compounds 3 and 1 (each within the scatter of the next); then compounds 4 and 2 (each within the scatter of the next).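

Exchanging the whole aryl group on the carbonyl carbon, rather than only a substituent on its ring, still leaves a nanomolar number in this assay, with modest steps (a 2.4-fold higher number from compound 1 to compound 4 (0.38 log units; beyond the scatter)) and (a 3.8-fold higher number from compound 3 to compound 4 (0.57 log units; beyond the scatter)). Against the 4-methoxyphenyl ester, the step (a 1.1-fold lower number from compound 2 to compound 4 (0.03 log units; within the scatter)) lies within the scatter, so compound 4 and compound 2 cannot be told apart. The ester position therefore accepts 2-phenylethenyl as well as the aryl groups.

As far as these compounds go, a saturated alkyl chain or an amine-bearing group at this position remains open, as does the effect of a substituent on the 2-phenylethenyl ring. No supporting data bear on what underlies these steps.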